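The source may report more compounds than this note shows. Statements on the series, on what has been measured and on what is new or still open speak of the compounds shown alone.

In a functional assay on DU-145 cells (Homo sapiens) for cytotoxicity, read by trypan blue exclusion, with a stated time of 96 h (on this read-out higher numbers stand for weaker inhibition and lower numbers for stronger inhibition), compound 2 `COC(=O)C(Nc1cc(CS(=O)(=O)/C=C/c2c(OC)cc(OC)cc2OC)ccc1OC)c1ccccc1` gives 75 nM, the lower of the two numbers recorded so far, while compound 1 `COc1cc(OC)c(/C=C/[S+]([O-])Cc2ccc(OC)c([N+](=O)[O-])c2)c(OC)c1` gives 15000 nM. Compound 3 `COc1cc(OC)c(/C=C/S(=O)(=O)Cc2ccc(OC)c(NC(C(=O)O)c3ccc(F)cc3)c2)c(OC)c1` remains unmeasured. It differs from compound 2 in a single place: carboxy(4-fluorophenyl)methyl in place of methoxycarbonyl)(benzyl on a nitrogen on an aromatic ring. Among the measured compounds shown here, no step between measured compounds matches this change, so the expectation rests on compound 2 alone. A modest step is expected, a 2.0-fold higher number from compound 2 to compound 3 (0.30 log units; within the scatter), toward a somewhat higher number, though a result within the scatter would not surprise. Compound 3 is thus estimated at 150 nM, with a range from 40 nM to 600 nM.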

Compound 3, half-maximal inhibitory concentration: 150 nM
Beside the measured number, compound 3's estimate shows no gap at the digits printed, and the stated range covers the measured number.
By their numbers in this assay, from the lowest: compounds 2 and 3 (each within the scatter of the next); then compound 1.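

In this assay, the exchange on this nitrogen gives a 2.0-fold higher number from compound 2 to compound 3 (0.30 log units; within the scatter), the first sign that this position accepts carboxy(4-fluorophenyl)methyl in place of methoxycarbonyl)(benzyl without a step beyond the scatter. The exchange alters the carboxy group and the fluorine together. The step cannot be divided between them. Nothing available explains this result. From the compounds shown here alone, whether either alteration alone would give the same result remains open. So does the outcome with an amide in place of the carboxy group, or with chlorine in place of the fluorine.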